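This account rests on a few compounds, and the source may have more. Where it says the series, first, only, none or still open, it means among the compounds named here.

Measured compounds:

Compound 1 `COc1ccc(N(Cc2ccc(F)cc2)NC(=O)NCCCN2CCN(c3ccccc3OC)CC2)cc1` — 2.9 nM
Compound 2 `C=CCN(NC(=O)NCCCN1CCN(c2ccccc2OC)CC1)c1ccc(OC)cc1` — 61 nM

In an assay on CHO cells for displacement of a labelled ligand from D(4) dopamine receptor (Homo sapiens), read by radioligand binding (a lower number here means a stronger inhibitor, a higher number a weaker inhibitor), compound 1 gives 2.9 nM, while compound 2 gives 61 nM, the higher of the two numbers and so the weaker binder. Among the compounds with values here, the only measured step, a 21-fold higher number from compound 1 to compound 2 (1.32 log units; beyond the scatter), exchanges a 4-fluorophenyl for a vinyl on the saturated chain carbon bound to the aromatic nitrogen.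

Compound 3 `C=C(C)CN(NC(=O)NCCCN1CCN(c2ccccc2OC)CC1)c1ccc(OC)cc1` differs from compound 2 by methyl in place of hydrogen on a double-bonded chain carbon bound to a saturated chain carbon. Within the data shown here, no measured step concerns adding a methyl to this vinyl; the step from compound 1 to compound 2 is a different kind of change, so it offers only a loose guide. With just one carbon entering at the double bond, compound 3 is expected to shift by a 1.2-fold lower number from compound 2 to compound 3 (0.09 log units; within the scatter), a step not beyond the scatter. The estimate for compound 3 is therefore 50 nM, with a range from 18 nM to 140 nM.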

Compound 3, inhibition constant: 64 nM
For compound 3 the middle estimate is 1.3-fold (0.11 log units) below the measured one, and the stated range covers the measured number.
By their numbers in this assay, from the lowest: compound 1; then compounds 2 and 3 (each within the scatter of the next).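

In this assay, methyl in place of hydrogen on the double-bonded chain carbon gives a 1.0-fold higher number from compound 2 to compound 3 (0.02 log units; within the scatter) and so within the scatter, which means that at this place the two compounds cannot be told apart. Replacing 4-fluorophenyl with 1-methylethenyl gives a 22-fold higher number from compound 1 to compound 3 (1.34 log units; beyond the scatter) and stays beyond the scatter, so compound 1 remains clearly separate from both compounds that carry a double bond at this place. No evidence here explains either result.

The compounds shown leave open whether the fluorine or the phenyl ring itself matters in compound 1, which a plain phenyl in place of the 4-fluorophenyl would help to separate. They also leave open how a saturated propyl chain or a longer chain ending in a double bond would read at this place.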